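Swapping a nitrile for two methyls on a sulfonamide aryl

The source may report more compounds than this note shows. Statements on the series, on what has been measured and on what is new or still open speak of the compounds shown alone.

Measured compounds in an ADME assay on HCT-116 cells (Homo sapiens) for cytotoxicity, read by CellTiter-Glo, with a stated time of 72 h; a higher number here means a weaker inhibitor, a lower number a stronger inhibitor:
- compound 1 `CC1CCN(C2CCN(S(=O)(=O)c3ccc(C#N)cc3)CC2)CC1`: > 5000 nM, a limit of the assay
- compound 2 `COc1ccccc1-c1ccc(S(=O)(=O)N2CCC(N3CCC(C)CC3)CC2)cc1`: > 5000 nM, a limit of the assay

For the measured compounds named here, compound 1 stands only at a limit in this assay, not at a number, and the limit of > 5000 nM in this assay, at which 2 of the 2 values shown sit, shows that the one other value known sits at the same limit. Going by the values given here, the step that the two limits leave unreadable from compound 1 to compound 2 is therefore unreadable from the two limits, and no measured step gives any size to work from.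

Compound 3 `Cc1ccc(S(=O)(=O)N2CCC(N3CCC(C)CC3)CC2)cc1C` differs from compound 1 in one place: 3,4-dimethylphenyl in place of 4-cyanophenyl on a sulfonyl sulfur. The change from compound 1 to compound 2 also replaced the cyano group at this position, and both values stayed at the limit, so no step beyond the scatter is expected here.

Compound 3 is estimated at 8000 nM, within 3000 nM to 30000 nM, most likely again reported only as a limit. That estimate means an expected step that the limit leaves unreadable from compound 1 to compound 3.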

Compound 3, half-maximal inhibitory concentration: > 5000 nM
Compound 3 was reported as a limit (the forecaster's own chance of this, stated with the estimate: 75%); the middle value does not contradict the limit.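

For the compounds shown here, compound 3, like compound 1, is reported only as a limit, so no step between the two can be read: the limit of > 5000 nM in this assay, at which 3 of the 3 values shown sit.

As far as these compounds go, whether any other group on the sulfonyl sulfur would give an actual number in this assay stays open, as does how far compound 1 and compound 3 lie past that limit.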